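A few compounds are considered here, and "the series" means these few. Any claim that something is new, unique, unknown or untested is made for them only; others in the source may bear on it.

Measured so far in an ADME assay on PC-3 cells (Homo sapiens) for cytotoxicity, read by WST assay, tested at 100 uM; a lower number here means less inhibition, a higher number more inhibition at the concentration tested (going by the name of the read-out):
compound 1 `CC(C)(C)CC(=O)Nc1cccc(C(=O)N2CCCC(C(=O)Nc3ccc(Cl)cc3)C2)c1` gives 0%
compound 2 `O=C(Nc1cccc(OCCc2ccccn2)c1)C1CCCN(C(=O)c2cc(C(F)(F)F)cc(C(F)(F)F)c2)C1` gives 5%

In this assay compound 1 and compound 2 sit close together, their two values within the usual scatter of each other, and both show little inhibition at the tested concentration. Compound 3 `Cc1nc(-c2cccc(C(=O)N3CCCC(C(=O)Nc4ccc(Cl)cc4)C3)c2)cs1` differs from compound 1 in one place: 2-methyl-1,3-thiazol-4-yl in place of (neopentylcarbonyl)amino on an aromatic carbon. Going by the values given here, no measured pair shows this exact change, so its effect cannot be read from the data. Because compound 1 gives 0% and compound 2 gives 5%, compound 3 is also expected to show little inhibition, with a step of a number 8 percentage points higher from compound 1 to compound 3 (within the scatter) expected to stay within the scatter. For compound 3 the estimate is 8%, between 0% and 30%.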

Compound 3, a percentage reported as inhibition, at one concentration (the size of the read-out at that concentration, not a potency): 1%
Beside the measured number, compound 3's estimate is 7 percentage points above it; low and high end bracket the measured number.
By their numbers in this assay, from the lowest: compounds 1, 3 and 2 (each within the scatter of the next).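

Going by these compounds alone, this is the first one-place comparison in the set: in this assay, 2-methyl-1,3-thiazol-4-yl in place of (neopentylcarbonyl)amino on this aromatic carbon gives a number 1 percentage points higher from compound 1 to compound 3 (within the scatter). The read-out does not separate these two groups, although the group that enters has a five-membered aromatic ring and no hydrogen-bond donor, while the one that leaves has no ring and one donor. Nothing measured here gives a reason for this result. Going by these compounds, whether an amine or a carboxylic acid on this carbon would give a similar reading stays open.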